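The compounds below may be only part of what the source reports. "The series", "measured", "known", "first", "only" and "open" are said of these compounds alone.

Measured in a functional assay on RT-112 cells (Homo sapiens) for antiproliferative activity, read by MTT assay, with a stated time of 72 h; on this read-out higher numbers stand for weaker inhibition of growth and lower numbers for stronger inhibition of growth:

- Compound 1 `COc1cc(NC(=O)Nc2cccc3c(Nc4cc(OC)cc(OC)c4)ncnc23)cc(OC)c1`: 366 nM
- Compound 2 `COc1cc(Nc2ncnc3c(NC(=O)Nc4ccc(C)c(C)c4)cccc23)cc(OC)c1`: 8.8 nM
- Compound 3 `COc1cc(Nc2ncnc3c(NC(=O)Nc4ccc(Cl)c(C(F)(F)F)c4)cccc23)cc(OC)c1`: > 20000 nM

Compound 3 reads > 20000 nM, which is a limit of the assay and not a number. It is the weakest of the three. Compound 4 `COc1cc(Nc2ncnc3c(NC(=O)Nc4cc(C)cc(C)c4)cccc23)cc(OC)c1` keeps the shared core and carries 3,5-dimethylphenyl in place of 4-chloro-3-(trifluoromethyl)phenyl on an amide-type nitrogen.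

Two measured steps introduce the departing group, and both are large: an at least 2200-fold higher number from compound 2 to compound 3 (3.35 log units; beyond the scatter) and an at least 54-fold higher number from compound 1 to compound 3 (1.73 log units; beyond the scatter). The nearest relative of compound 4 is compound 2, with its 3,4-dimethylphenyl group and its value of 8.8 nM. Removing the departing group should therefore again bring a large change, towards a lower number in this assay.

The expected step is an at least 400-fold lower number from compound 3 to compound 4 (2.60 log units; beyond the scatter). For compound 4 the estimated value is 50 nM, with an expected range of 8 nM to 400 nM.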

Compound 4, concentration for 50% growth inhibition: 10100 nM
Compound 4: the middle estimate sits 200-fold (2.31 log units) below what was measured; measured number outside the range, above it.
By their numbers in this assay, from the lowest: compound 2; then compound 1; then compound 4. At a limit, above all of these: compound 3.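

In this assay, both groups carry two methyls, yet a 1100-fold higher number from compound 2 to compound 4 (3.06 log units; beyond the scatter), so on this amide-type nitrogen the placing of the methyls on the phenyl ring matters, not merely their presence. The choice of group also counts, with a 28-fold higher number from compound 1 to compound 4 (1.44 log units; beyond the scatter), while an at least 1.9-fold lower number from compound 3 to compound 4 (0.29 log units; that floor lies within the scatter), so this change gives no clear recovery of activity. Compound 3 stands at a limit and not at a number: the limit of > 20000 nM in this assay, at which 1 of the 4 values shown sits.

Still open, as far as these compounds go, is whether a single methyl, as in 4-methylphenyl, is enough for strong activity. From the compounds shown here alone, how 3,4-dimethoxyphenyl would compare with 3,4-dimethylphenyl also remains unknown.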